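The compounds below may be only part of what the source reports. "The series", "measured", "known", "first", "only" and "open" are said of these compounds alone.

Working notes on the series. Compound 1 `CCC1=C(O)c2c(oc(-c3ccc(C)cc3)cc2=O)C(CC)(CC)C1=O` gives 0.08 uM in a functional assay on KBVIN cells (Homo sapiens) for antiproliferative activity, read by sulforhodamine B assay, with a stated time of 3 days; on this read-out lower numbers stand for an effect already at smaller amounts and higher numbers for an effect only at larger amounts of compound. Compound 2 `CCC1=C(O)c2c(oc(-c3ccc(OC)cc3)cc2=O)C(CC)(CC)C1=O` gives 0.68 uM, and compound 3 `CCC1=C(O)c2c(oc(-c3ccc(C)c(C)c3)cc2=O)C(CC)(CC)C1=O` gives 0.71 uM. Compound 3 carries the highest number of the three: against compound 2 it lies within the scatter, while an 8.9-fold higher number from compound 1 to compound 3 (0.95 log units; beyond the scatter) puts it beyond the scatter against compound 1. Compound 4 `CCC1=C(O)c2c(oc(-c3cc(C)ccc3C)cc2=O)C(CC)(CC)C1=O` differs from compound 3 by 2,5-dimethylphenyl in place of 3,4-dimethylphenyl on an aromatic carbon. The measured steps that touch this ring are an 8.5-fold higher number from compound 1 to compound 2 (0.93 log units; beyond the scatter) and an 8.9-fold higher number from compound 1 to compound 3 (0.95 log units; beyond the scatter), both modest, whereas a 1.0-fold higher number from compound 2 to compound 3 (0.02 log units; within the scatter) is flat. None of them moves a methyl from one aromatic carbon to another, and the atoms stay the same. No step beyond the scatter is expected: a 1.0-fold lower number from compound 3 to compound 4 (0.01 log units; within the scatter). Compound 4 is estimated at 0.7 uM, within 0.25 uM to 2 uM.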

Compound 4, concentration for half-maximal effect: 3.41 uM
Beside the measured number, compound 4's estimate is 4.9-fold (0.69 log units) below it; the whole stated range lies below it.
By their numbers in this assay, from the lowest: compound 1; then compounds 2 and 3 (each within the scatter of the next); then compound 4.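

With the atoms unchanged, rearranging the methyls into 2,5-dimethylphenyl is not flat: a 4.8-fold higher number from compound 3 to compound 4 (0.68 log units; beyond the scatter), so on this phenyl group the arrangement of the methyls counts, not only their number. The same group also separates compound 4 from compound 2, a 5.0-fold higher number from compound 2 to compound 4 (0.70 log units; beyond the scatter), although compound 2 and compound 3 sit level. Against compound 1 it gives the widest gap in the set, a 43-fold higher number from compound 1 to compound 4 (1.63 log units; beyond the scatter). Nothing available explains this loss. Also open, on these data alone, is how an amine or a carboxylic acid in place of the methyl of compound 1 would read.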